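Imidazopyridine to benzimidazole on the acetamide arm: expected readout

This account rests on a few compounds, and the source may have more. Where it says the series, first, only, none or still open, it means among the compounds named here.

Measured so far:
Compound 1 `CCOc1ncc(-c2nc(C(F)(F)F)sc2N2CCN(C(=O)Cn3cnc4cccnc43)[C@H](C)C2)cn1` gives 48 nM in an assay on blood for inhibition of C-X-C chemokine receptor type 3 (Homo sapiens), with a stated time of 30 min; a higher number here means a weaker inhibitor, a lower number a stronger inhibitor.
Compound 2 `Cc1ncc(-c2nc(C(F)(F)F)sc2N2CCN(C(=O)Cn3cnc4cccnc43)[C@H](C)C2)cn1` gives 104 nM in this assay.
Compound 3 `CCCc1ncc(-c2nc(C(F)(F)F)sc2N2CCN(C(=O)Cn3cnc4cccnc43)[C@H](C)C2)cn1` gives 45 nM in this assay.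

Compound 1 stands second highest of the three numbers; compound 3 is nearest, with a 1.1-fold lower number from compound 1 to compound 3 (0.03 log units; within the scatter), and compound 2 is furthest, with a 2.2-fold higher number from compound 1 to compound 2 (0.34 log units; beyond the scatter). The steps recorded so far all concern the substituent on the shared core's aromatic carbon: methyl in place of ethoxy, propyl in place of ethoxy, and ethyl in place of hydrogen, the last giving a 2.3-fold lower number from compound 2 to compound 3 (0.36 log units; beyond the scatter). None of them touch the part that changes in compound 4 `CCOc1ncc(-c2nc(C(F)(F)F)sc2N2CCN(C(=O)Cn3cnc4ccccc43)[C@H](C)C2)cn1`, where the difference from compound 1 is a group of 9 heavy atoms (7 carbon, 2 nitrogen; one five-membered aromatic ring with 2 hetero atoms, one six-membered aromatic ring of carbon only) in place of a group of 9 heavy atoms (6 carbon, 3 nitrogen; one five-membered aromatic ring with 2 hetero atoms, one six-membered aromatic ring with 1 hetero atom), on a saturated chain carbon bound to a carbonyl carbon. Among the measured compounds shown here, no measured step bears directly on this exchange, so there is no basis in these three compounds for expecting a shift beyond the scatter in either direction. Compound 4 is therefore estimated at 60 nM, with a range of 25 nM to 150 nM, meaning an expected step of a 1.3-fold higher number from compound 1 to compound 4 (0.10 log units; within the scatter).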

Compound 4, half-maximal inhibitory concentration: 192 nM
Estimate against measurement, compound 4: 3.2-fold (0.51 log units) below, outside the stated range (above it).
By their numbers in this assay, from the lowest: compounds 3 and 1 (each within the scatter of the next); then compounds 2 and 4 (each within the scatter of the next).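

In this assay, the position on the saturated chain carbon bound to a carbonyl carbon proves sensitive: 1H-benzimidazol-1-yl in place of the group in compound 1 gives a 4.0-fold higher number from compound 1 to compound 4 (0.60 log units; beyond the scatter), a weaker inhibitor. The two groups have the same heavy-atom count and differ in the six-membered aromatic ring, which carries 1 hetero atom in compound 1 and is carbon only in compound 4, so this ring nitrogen matters to the read-out, something the earlier substituent changes on the aromatic carbon could not show. No measurement at hand accounts for the step.

Going by these compounds, whether the step holds with methyl or propyl in place of ethoxy remains open. Also open, on these data alone, is how a 1H-indol-1-yl group or a smaller 1H-imidazol-1-yl group would read at this position.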